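A few compounds are considered here, and "the series" means these few. Any claim that something is new, unique, unknown or untested is made for them only; others in the source may bear on it.

Measured compounds:
compound 1 `O=C(O)CC1(c2ccccc2)CCCN(C(=O)Nc2ccc(Cl)cc2)C1` — > 100000 nM
compound 2 `O=C(Nc1ccc(Cl)cc1)N1CCCC(CCCO)(c2ccccc2)C1` — > 100000 nM
compound 3 `NC(=O)CCC1(c2ccccc2)CCCN(C(=O)Nc2ccc(Cl)cc2)C1` — > 100000 nM

In an assay for inhibition of epoxide hydrolase 1 (Homo sapiens), using microsomes (on this read-out lower numbers stand for stronger inhibition and higher numbers for weaker inhibition), compound 1 gives only a limit, > 100000 nM, not a number. Compound 2 likewise reaches only the limit > 100000 nM. Compound 3 also stops at the limit > 100000 nM. All three values sit at the limit of > 100000 nM in this assay, at which 3 of the 3 values shown sit, so compound 1 cannot be placed against its neighbours.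

Compound 4 `O=C(CCC1(c2ccccc2)CCCN(C(=O)Nc2ccc(Cl)cc2)C1)NC1=NNNN1` differs from compound 1 by a group of 9 heavy atoms (3 carbon, 5 nitrogen, 1 oxygen; one five-membered non-aromatic ring with 4 hetero atoms) in place of a group of 3 heavy atoms (1 carbon, 2 oxygen; no ring), on a saturated chain carbon bound to a saturated ring carbon. The steps that touch the same place, a step that the two limits leave unreadable from compound 1 to compound 2 and a step that the two limits leave unreadable from compound 1 to compound 3, are both unreadable, as is a step that the two limits leave unreadable from compound 2 to compound 3. For the measured compounds named here, no measured step therefore gives a size or a direction for the change to compound 4; the series so far shows only that exchanges at this chain carbon have left every compound at the limit.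

Compound 4 is expected to show a step of an at least 1.6-fold lower number from compound 1 to compound 4 (0.22 log units; that floor lies within the scatter), with the estimate 60000 nM and a range from 5000 nM to 200000 nM.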

Compound 4, half-maximal inhibitory concentration: > 100000 nM
Compound 4: a limit, no number (the forecaster's own chance of this, stated with the estimate: 65%); middle value at least 1.6-fold (0.22 log units) from the limit.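

In this assay compound 4 gives only a limit, so the steps to it from compound 1, compound 2 and compound 3 cannot be read: the limit of > 100000 nM in this assay, at which 4 of the 4 values shown sit.

Left open is whether any group at this saturated chain carbon gives a number rather than a limit.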